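Replacing Methylsulfamoyl with Tetrazolyl on the Shared Core

A few compounds are considered here, and "the series" means these few. Any claim that something is new, unique, unknown or untested is made for them only; others in the source may bear on it.

Compound 1 `CCCS(=O)(=O)Nc1ccc(F)c(C(=O)c2n[nH]c3ncc(-c4ccc([N+](=O)[O-])cc4)cc23)c1F` gives 4.2% in an assay for binding affinity to dual specificity mitogen-activated protein kinase kinase 4 (Homo sapiens), read by KINOMEscan, tested at 100 nM; on this read-out lower numbers stand for a stronger effect and higher numbers for a weaker effect at the one concentration tested. Compound 2 `CCCS(=O)(=O)Nc1ccc(F)c(C(=O)c2n[nH]c3ncc(-c4ccc(S(=O)(=O)NC)cc4)cc23)c1F`, which carries methylsulfamoyl in place of nitro on an aromatic carbon, gives 1.2% in this assay, and the step of a number 3 percentage points lower from compound 1 to compound 2 (within the scatter) is within the scatter. Compound 2 thus holds the lowest of the two numbers, with compound 1 nearest and within the scatter of it.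

Compound 3 `CCCS(=O)(=O)Nc1ccc(F)c(C(=O)c2n[nH]c3ncc(-c4ccc(-c5nnn[nH]5)cc4)cc23)c1F` has not yet been measured. It differs from compound 2 by 1H-tetrazol-5-yl in place of methylsulfamoyl on an aromatic carbon. Among the measured compounds shown here, the only measured step at this place is a number 3 percentage points lower from compound 1 to compound 2 (within the scatter), which stayed within the scatter, so a change at this position has so far not moved the read-out beyond it.

Compound 3 is therefore expected to give 3% in this assay, within a range from 0% to 15%. The expected step is a number 1.8 percentage points higher from compound 2 to compound 3 (within the scatter), that is, none beyond the scatter.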

Compound 3, a percentage reported as activity, at one concentration (the size of the read-out at that concentration, not a potency): 0.15%
Beside the measured number, compound 3's estimate is 2.9 percentage points above it; measured number inside the range.
By their numbers in this assay, from the lowest: compounds 3, 2 and 1 (each within the scatter of the next).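

In this assay, a ring now stands at this place on the shared core: 1H-tetrazol-5-yl in place of methylsulfamoyl gives a number 1.1 percentage points lower from compound 2 to compound 3 (within the scatter), and in place of nitro it gives a number 4.1 percentage points lower from compound 1 to compound 3 (within the scatter). Among the compounds shown here, the position thus carries three different groups, one of them a five-membered aromatic ring with 4 hetero atoms, and no step among them passes the scatter. Nothing at hand accounts for this result.

Whether a carboxylic acid, an amine or a plain hydrogen at this place would move the read-out beyond the scatter stays open, since none of the groups shown does so. As far as these compounds go, with a single concentration in this assay, it also stays open whether these three compounds differ in potency at all.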